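Replacing furan-3-yl with 4-(methylsulfonyl)phenyl in compound 2

The source may hold more compounds than are shown below. What is called first, only, known or untested is meant among the compounds shown, and "the series" means these compounds.

Measured in an ADME assay (liver) for metabolic stability, with Liver microsome (Rattus norvegicus) as the target, using microsomes and NADPH, with a stated time of 30 min, tested at 1 uM; on this read-out higher numbers stand for fast clearance and lower numbers for slow clearance:
Compound 1 `Nc1ccc(S(=O)(=O)N2CCN(c3ncc(C(O)(C(F)(F)F)C(F)(F)F)cc3Br)CC2)cn1`: 32 mL.min-1.g-1
Compound 2 `Nc1ccc(S(=O)(=O)N2CCN(c3ncc(C(O)(C(F)(F)F)C(F)(F)F)cc3-c3ccoc3)CC2)cn1`: 57 mL.min-1.g-1

Compound 2, at 57 mL.min-1.g-1, cannot be separated from compound 1 on these numbers, as the two values lie within the scatter of each other. The next compound in the account, compound 3 `CS(=O)(=O)c1ccc(-c2cc(C(O)(C(F)(F)F)C(F)(F)F)cnc2N2CCN(S(=O)(=O)c3ccc(N)nc3)CC2)cc1`, carries 4-(methylsulfonyl)phenyl in place of furan-3-yl on an aromatic carbon.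

Within the data shown here, only one measured step bears on this change. It is the exchange of bromo for furan-3-yl on that same aromatic carbon, a 1.8-fold higher number from compound 1 to compound 2 (0.25 log units; within the scatter). Among the measured compounds shown here, that single step stayed within the scatter, but it is thin evidence, and no measured compound carries 4-(methylsulfonyl)phenyl. On these data alone, on this basis, no shift beyond the scatter is expected in this assay, and the direction remains open, with a slight drop taken as the working guess. The estimate amounts to an expected 1.3-fold lower number from compound 2 to compound 3 (0.10 log units; within the scatter). For compound 3 the estimated value is 45 mL.min-1.g-1, with an expected range from 18 mL.min-1.g-1 to 110 mL.min-1.g-1.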

Compound 3, intrinsic clearance in microsomes: 103 mL.min-1.g-1
For compound 3 the middle estimate is 2.3-fold (0.36 log units) below the measured one; measured number inside the range.
By their numbers in this assay, from the lowest: compounds 1, 2 and 3 (each within the scatter of the next, the first and the last beyond it).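

In this assay, this aromatic carbon now gives its first step beyond the scatter, a 3.2-fold higher number from compound 1 to compound 3 (0.51 log units; beyond the scatter), with 4-(methylsulfonyl)phenyl in place of bromo, although the printed label of that step marks it as modest. The exchange of furan-3-yl for 4-(methylsulfonyl)phenyl gives a 1.8-fold higher number from compound 2 to compound 3 (0.26 log units; within the scatter), so these two ring-bearing groups cannot be told apart on this read-out, even though the entering group has 10 heavy atoms against 5 and brings a six-membered carbon ring in place of a five-membered ring with one hetero atom. Compound 2 thus stands within the scatter of both compound 1 and compound 3, and nothing available here accounts for the gap between the two ends of the series.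

The compounds shown leave open whether the higher number of compound 3 goes with the phenyl ring itself or with its methylsulfonyl group, as the two enter together. A plain phenyl group at this carbon would separate the two, and a small group such as a methyl or an amine would show whether any replacement for bromo can give a number lower than that of compound 1.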